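A few compounds are considered here, and "the series" means these few. Any claim that something is new, unique, unknown or untested is made for them only; others in the source may bear on it.

Measured compounds in the series:

- Compound 1, `CC(/C=N/Nc1ccc([N+](=O)[O-])cc1)=N\NC(=O)c1ccc(O)cc1`. In a functional assay on cells (Splenocyte, Mus musculus, strain BALB/c) for inhibition, read by scintillation counting and thymidine incorporation, with a stated time of 72 h (on this read-out lower numbers stand for stronger inhibition and higher numbers for weaker inhibition), compound 1 gives 1510 nM.
- Compound 2, `CC(/C=N/Nc1ccc([N+](=O)[O-])cc1)=N\NC(=O)c1cccc(C)c1`. For compound 2 this assay reports only a limit, > 12000 nM.
- Compound 3, `CC(/C=N/Nc1ccc([N+](=O)[O-])cc1)=N\NC(=O)c1ccc([N+](=O)[O-])cc1`. In this assay compound 3 gives 980 nM.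

Compound 3 holds the lowest of the two numbers shown; its nearest neighbour is compound 1, and that gap, a 1.5-fold lower number from compound 1 to compound 3 (0.19 log units; within the scatter), lies within the scatter. The third value is a limit (the limit of > 12000 nM in this assay, at which 1 of the 3 values shown sits). The steps that do reach beyond the scatter both involve the 3-methylphenyl compound: an at least 7.9-fold higher number from compound 1 to compound 2 (0.90 log units; beyond the scatter) and an at least 12-fold lower number from compound 2 to compound 3 (1.08 log units; beyond the scatter).

Compound 4, `CC(/C=N/Nc1ccc([N+](=O)[O-])cc1)=N\NC(=O)c1ccc(Cl)cc1`, is not yet measured. It differs from compound 3 by chloro in place of nitro on an aromatic carbon. For the measured compounds named here, the only measured step at that same aromatic carbon, a 1.5-fold lower number from compound 1 to compound 3 (0.19 log units; within the scatter), stayed within the scatter; no measured step carries a chloro there. The expectation for this assay is therefore a step of a 1.5-fold higher number from compound 3 to compound 4 (0.18 log units; within the scatter), within the scatter or at most a slight weakening. Compound 4 is estimated at 1500 nM, between 600 nM and 4000 nM.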

Compound 4, half-maximal inhibitory concentration: 4200 nM
Compound 4: middle estimate off by 2.8-fold (0.45 log units), on the low side, outside the stated range (above it).
By their numbers in this assay, from the lowest: compounds 3 and 1 (each within the scatter of the next); then compound 4. At a limit, above all of these: compound 2.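

The aromatic carbon para to a large group is not indifferent to its substituent in this assay: hydroxy and nitro there stay within the scatter of each other, but chloro gives steps beyond it from both (a 4.3-fold higher number from compound 3 to compound 4 (0.63 log units; beyond the scatter); a 2.8-fold higher number from compound 1 to compound 4 (0.44 log units; beyond the scatter)). The earlier compounds shown here showed a large change only with the 3-methylphenyl group, whereas here a single replacement at this carbon moves the number beyond the scatter. The 4-chlorophenyl group still stands clear of the 3-methylphenyl group (an at least 2.8-fold lower number from compound 2 to compound 4 (0.45 log units; beyond the scatter)), though that step rests on a limit and not a number: the limit of > 12000 nM in this assay, at which 1 of the 4 values shown sits.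

On these data alone, whether an amine or a carboxylic acid at this carbon would fall with hydroxy and nitro or with chloro remains open. So does whether a methyl at this same carbon would behave like the 3-methylphenyl group.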